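The source may hold more compounds than are shown below. What is called first, only, known or untested is meant among the compounds shown, and "the series" means these compounds.

Of the compounds shown here, two of the shared core have been measured in a functional assay on Ehrlich cells (Mus musculus) for cytotoxicity, tested at 25 ug/mL; a lower number here means a weaker effect, a higher number a stronger effect of the compound at the concentration tested. Compound 1, `N#Cc1c(N/N=C2/C(=O)NN=C2N)sc2c1CCCC2`, gives 94% in this assay. Compound 2, `CC1=NNC(=O)/C1=N/Nc1sc2c(c1C(N)=O)CCCC2`, gives 38.1% in this assay, the lower of the two numbers; the gap to compound 1 lies well beyond the scatter. Among the compounds with values here, compounds 1 and 2 differ in two places, so no single step connects them and their values only show the spread of the series so far.

Compound 3, `NC(=O)c1c(N/N=C2/C(=O)NN=C2N)sc2c1CCCC2`, is not yet measured. It differs from compound 2 by amino in place of methyl on a carbon with a double bond to nitrogen, which brings in the amino that compound 1 also carries. Given that compound 1 gives 94% in this assay, a rise from compound 2 is expected, but only a moderate one, because compound 2 itself gives 38.1% while carrying the other feature that compound 3 keeps. Compound 3 is expected at about 58% in this assay, within 32% to 85%, that is an expected step of a number 19.9 percentage points higher from compound 2 to compound 3 (beyond the scatter) beyond the scatter.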

Compound 3, a percentage reported as activity, at one concentration (the size of the read-out at that concentration, not a potency): 65%
Beside the measured number, compound 3's estimate is 7 percentage points below it, and the stated range covers the measured number.
By their numbers in this assay, from the lowest: compound 2; then compound 3; then compound 1.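

With compound 3, both places can be read on their own in this assay: amino in place of methyl on a carbon with a double bond to nitrogen gives a number 26.9 percentage points higher from compound 2 to compound 3 (beyond the scatter), and carbamoyl in place of cyano on an aromatic carbon gives a number 29 percentage points lower from compound 1 to compound 3 (beyond the scatter). Each place therefore carries a change beyond the scatter when the other place stays fixed, which the earlier pair, differing in two places, could not show. Within the data shown here, nothing measured so far explains either step.

From the compounds shown here alone, whether the amino step holds with cyano on the aromatic carbon, rather than carbamoyl, remains open. Also open, going by these compounds, is how a carboxylic acid on the aromatic carbon, or a dimethylamino or ethyl group in place of amino, would read in this assay.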